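Benzoyl for propanoyl on the phosphate-bearing acyclic side chain

This account rests on a few compounds, and the source may have more. Where it says the series, first, only, none or still open, it means among the compounds named here.

Measured so far:
Compound 1, `CCC(=O)OCC(COC(=O)CC)Cn1cnc2c(NC)nc(Cl)nc21`: in a functional assay for inhibition, with Rattus norvegicus as the target (a lower number here means a stronger inhibitor, a higher number a weaker inhibitor), compound 1 gives 23000 nM.
Compound 2, `CCC(=O)OCC(COP(=O)(O)O)Cn1cnc2c(NC)nc(Cl)nc21`: in this assay compound 2 gives 21000 nM.
Compound 3, `CNc1ncnc2c1ncn2CC(COP(=O)(O)O)COP(=O)(O)O`: in this assay compound 3 gives 510 nM.

Compound 2 stands second highest of the three numbers in this assay. Compound 1 sits within the scatter of it, as a 1.1-fold lower number from compound 1 to compound 2 (0.04 log units; within the scatter) shows. Within the data shown here, compound 3, with 510 nM, lies far from compound 2, beyond the scatter; no single-place step links these two, so only the two values themselves speak.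

Compound 4, `CNc1nc(Cl)nc2c1ncn2CC(COC(=O)c1ccccc1)COP(=O)(O)O`, differs from compound 2 by phenyl in place of ethyl on a carbonyl carbon. Among the measured compounds shown here, the only measured single-place step in the set, a 1.1-fold lower number from compound 1 to compound 2 (0.04 log units; within the scatter), concerns an oxygen on a saturated carbon and was flat. For the measured compounds named here, nothing measured here touches the carbonyl carbon, so no step bears directly on the change from ethyl to phenyl at that position. Going by the values given here, with no relevant precedent, the working expectation is no step beyond the scatter in this assay, in either direction.

For compound 4 the estimate in this assay is 20000 nM, with a range from 6000 nM to 70000 nM. The expected step, a 1.1-fold lower number from compound 2 to compound 4 (0.02 log units; within the scatter), is therefore essentially flat, with the range widened to reflect the absence of any comparable measured change.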

Compound 4, inhibition constant: 18000 nM
The estimate for compound 4 lay 1.1-fold (0.05 log units) above the measured number, and the stated range covers the measured number.
By their numbers in this assay, from the lowest: compound 3; then compounds 4, 2 and 1 (each within the scatter of the next).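

In this assay, among these compounds, the change from propanoyl to benzoyl gives a 1.2-fold lower number from compound 2 to compound 4 (0.07 log units; within the scatter), the first measured step at a carbonyl carbon. Phenyl, with one six-membered aromatic ring, can therefore replace ethyl, with no ring, without a step beyond the scatter, which the earlier step at an oxygen on a saturated carbon could not show. Nothing available explains why this step stays within the scatter.

The compounds shown leave open whether an amine or a carboxylic acid on this carbonyl carbon, or a longer chain in place of ethyl, would give a step beyond the scatter. Also open, from the compounds shown here alone, is which structural difference matters for compound 3, at 510 nM, since it differs from compound 2 in more than one place and no single change can be singled out from these values.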